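Three measured amides and one awaiting measurement

The source may report more compounds than this note shows. Statements on the series, on what has been measured and on what is new or still open speak of the compounds shown alone.

Compound 1 `CCCCCC(=O)c1ccc(OCCCN2CCN(C(=O)[C@@H](CC(C)C)NC(=O)OC(C)(C)C)CC2)cc1` in an assay for binding affinity to histamine H2 receptor (Homo sapiens) (on this read-out lower numbers stand for stronger inhibition and higher numbers for weaker inhibition), gives 4470 nM.
Compound 2 `CCCCCC(=O)c1ccc(OCCCN2CCN(C(=O)[C@@H](C)NC(=O)OC(C)(C)C)CC2)cc1` in this assay gives 10700 nM.
Compound 3 `CC(C)N[C@H](C)C(=O)N1CCN(CCCOc2ccc(C(=O)C3CC3)cc2)CC1` in this assay gives 50100 nM.

Compound 3 stands highest of the three numbers in this assay; its value lies beyond the scatter from that of compound 2 and further still from that of compound 1, so it is the weakest binder measured so far.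

Compound 4 `CCC[C@@H](N)C(=O)N1CCN(CCCOc2ccc(C(=O)C3CC3)cc2)CC1` has not yet been measured. It differs from compound 3 in one place: 1-aminobutyl in place of 1-(isopropylamino)ethyl on a carbonyl carbon.

For the measured compounds named here, only one measured step bears on this, and loosely: in this assay there is a 2.4-fold higher number from compound 1 to compound 2 (0.38 log units; beyond the scatter), a modest change when a side-chain branch is removed. Going by the values given here, the change from compound 3 to compound 4 moves in the other direction on the chain carbon, adding chain length there, while the substituent on the amine nitrogen is removed; no measured pair isolates that second part. Taken together the weight of the data is thin, and any expectation rests mainly on the chain-length step between compound 1 and compound 2.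

For compound 4 in this assay a modest lower number is expected, with the step estimated at a 2.0-fold lower number from compound 3 to compound 4 (0.30 log units; within the scatter). The estimate for compound 4 is 25000 nM, within a range from 8000 nM to 80000 nM.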

Compound 4, inhibition constant: 60300 nM
For compound 4 the middle estimate is 2.4-fold (0.38 log units) below the measured one; measured number inside the range.
By their numbers in this assay, from the lowest: compound 1; then compound 2; then compounds 3 and 4 (each within the scatter of the next).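

In this assay, exchanging 1-(isopropylamino)ethyl for 1-aminobutyl on a carbonyl carbon whose other neighbours are an amide-type nitrogen in a ring gives a step within the scatter (a 1.2-fold higher number from compound 3 to compound 4 (0.08 log units; within the scatter)). For the compounds shown here, this is the first reading at this position, and it differs from the only earlier step (a 2.4-fold higher number from compound 1 to compound 2 (0.38 log units; beyond the scatter)), which lies beyond the scatter but belongs to another pair and a different exchange. No supporting evidence bears on this result.

The exchange alters the substituent on the amine nitrogen and the chain on the same carbon together, so the small net step does not show whether each part alone has little effect or whether the two offset each other; 1-aminoethyl and 1-(isopropylamino)butyl at this position would separate the two parts. Compounds 3 and 4 also differ from compounds 1 and 2 in more than one place, so the contribution of the cyclopropyl ketone against the hexanoyl group, like that of the tert-butyl carbamate against a free amine, remains unread.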